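The source may hold more compounds than are shown below. What is called first, only, known or untested is meant among the compounds shown, and "the series" means these compounds.

Compound 1 `COc1nc(NC2CC2)c2ncn([C@H]3C[C@H](N=[N+]=[N-])[C@@H](CO)O3)c2n1`: > 100000 nM
Compound 2 `CC(C)(CO)Nc1nc(N)nc2c1ncn2[C@H]1C[C@H](N=[N+]=[N-])[C@@H](CO)O1`: > 100000 nM
Compound 3 `C=CCNc1ncnc2c1ncn2[C@H]1C[C@H](N=[N+]=[N-])[C@@H](CO)O1`: 51100 nM

In an ADME assay on PBMC cells (Homo sapiens) for cytotoxicity, with a stated time of 5 days (on this read-out lower numbers stand for stronger inhibition and higher numbers for weaker inhibition), compound 2 gives only a limit, > 100000 nM, not a number. Compound 1 likewise stops at a limit, > 100000 nM. Compound 2 therefore stands at the limit of > 100000 nM in this assay, at which 2 of the 3 values shown sit, with no number of its own to rank. Compound 3 alone gives a number, 51100 nM, in this assay.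

Compound 4 `CN(C)c1nc(N)nc2c1ncn2[C@H]1C[C@H](N=[N+]=[N-])[C@@H](CO)O1` is not yet measured. It differs from compound 2 by dimethylamino in place of (1-(hydroxymethyl)-1-methylethyl)amino on an aromatic carbon. Going by the values given here, with no measured step between two compounds to lean on, and compound 2 sitting at the limit, no step beyond the scatter is expected; the estimated step from compound 2 to compound 4 is a number no higher from compound 2 to compound 4 (the limit leaves the size open). Compound 4 is therefore expected to give about 100000 nM in this assay, within 30000 nM to 300000 nM, most likely again as a limit.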

Compound 4, half-maximal inhibitory concentration: > 100000 nM
Compound 4: a limit, no number; the forecaster's own chance of this, stated with the estimate: 75%; the middle value lies on the limit itself.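

Compound 2 and compound 4 both stop at a limit in this assay, so no step between them can be read: the limit of > 100000 nM in this assay, at which 3 of the 4 values shown sit.

The compounds shown leave open whether dimethylamino in place of (1-(hydroxymethyl)-1-methylethyl)amino on an aromatic carbon changes this read-out at all.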